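The compounds below may be only part of what the source reports. "The series", "measured", "known", "first", "only" and "open" are said of these compounds alone.

Series notes, bile acid receptor binding.

compound 1: `COC(=O)/C=C/c1ccc(CN(C(=O)C2CCCCC2)c2cccc(/C=C/C(=O)OC)c2)cc1` — in an assay on isolated protein with Bile acid receptor (Homo sapiens) as the target (on this read-out higher numbers stand for an effect only at larger amounts of compound and lower numbers for an effect already at smaller amounts), compound 1 gives > 1000 nM, a limit of the assay rather than a number.
compound 2: `COC(=O)/C=C/c1cccc(N(Cc2ccc(-c3ccc(SC)cc3)cc2)C(=O)C2CCCCC2)c1` — in this assay compound 2 gives 69 nM.

For the measured compounds named here, compound 2 holds the only number in the set; the other value shown is a limit, see (the limit of > 1000 nM in this assay, at which 1 of the 2 values shown sits). One measured step exists, an at least 14-fold lower number from compound 1 to compound 2 (1.16 log units; beyond the scatter), and it exchanges a whole group for 4-(methylsulfanyl)phenyl at a different place from the change now considered.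

Compound 3, `COC(=O)/C=C/c1cccc(N(Cc2ccc(-c3ccc(OC(F)(F)F)cc3)cc2)C(=O)C2CCCCC2)c1`, differs from compound 2 by trifluoromethoxy in place of methylsulfanyl on an aromatic carbon. Going by the values given here, no measured step swaps one substituent for another on this outer ring, so the step from compound 1 to compound 2 offers only a loose guide: it shows that this end of the molecule matters, not how two substituents on the same phenyl compare. In this assay a change within the scatter is therefore expected, with no direction favoured. Compound 3 is estimated at 80 nM, range 25 nM to 300 nM, which corresponds to an expected step of a 1.2-fold higher number from compound 2 to compound 3 (0.06 log units; within the scatter).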

Compound 3, half-maximal effective concentration: 264 nM
Estimate against measurement, compound 3: 3.3-fold (0.52 log units) below; the measured number falls inside the stated range.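

In this assay, the substituent para to a large group on this aromatic carbon does affect the read-out: trifluoromethoxy in place of methylsulfanyl gives a 3.8-fold higher number from compound 2 to compound 3 (0.58 log units; beyond the scatter), so the two groups cannot be treated as interchangeable here. The outer phenyl keeps part of its advantage with either substituent, since 4-(trifluoromethoxy)phenyl in place of 2-(methoxycarbonyl)ethenyl still gives an at least 3.7-fold lower number from compound 1 to compound 3 (0.57 log units; beyond the scatter), which shows that the lower numbers of this pair of compounds do not rest on methylsulfanyl alone. The value of compound 1 is a limit of the assay rather than a number, so this step has a bound and not a fixed size: the limit of > 1000 nM in this assay, at which 1 of the 3 values shown sits.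

The compounds shown leave open how other groups on this carbon would read, such as methoxy, chlorine, a nitrile or an amine, and so whether methylsulfanyl is an unusually good substituent or trifluoromethoxy an unusually poor one. They also leave open whether the same exchange would give a step of similar size with a carboxylic acid in place of the methyl ester on the ethenyl chain.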